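Swapping the trifluoromethyl for an amino group on compound 1

This account rests on a few compounds, and the source may have more. Where it says the series, first, only, none or still open, it means among the compounds named here.

Within the data shown here, compound 1, `Cc1c(C(=O)NCc2cccc(C(F)(F)F)c2)cnn1-c1ccc(Cl)cc1`, is the only compound in this set to give an actual number: in a functional assay on cells for antagonist activity at C-C chemokine receptor type 1 (Homo sapiens), read by FLIPR and calcium flux (a higher number here means a weaker inhibitor, a lower number a stronger inhibitor), compound 1 gives 600 nM. Compound 2, `Cc1c(C(=O)NCc2cccc(C(F)(F)F)c2)cnn1-c1cccc(Cl)c1`, gives > 3000 nM in this assay, which is a limit rather than a number. Compound 3, `Nc1c(C(=O)NCc2cccc(C(F)(F)F)c2)cnn1-c1ccc(Cl)cc1`, likewise gives only the limit > 3000 nM in this assay. The two measured steps, an at least 5.0-fold higher number from compound 1 to compound 2 (0.69 log units; beyond the scatter) and an at least 5.0-fold higher number from compound 1 to compound 3 (0.69 log units; beyond the scatter), both run from compound 1 toward weaker inhibition, and both reach (the limit of > 3000 nM in this assay, at which 2 of the 3 values shown sit). Compound 4, `Cc1c(C(=O)NCc2cccc(N)c2)cnn1-c1ccc(Cl)cc1`, differs from compound 1 by amino in place of trifluoromethyl on an aromatic carbon. Neither measured step touches this part of the molecule, so the change is not directly informed; the two steps only show that single changes to compound 1 have so far cost at least a modest amount of activity. The expected step from compound 1 to compound 4 is therefore estimated as a 5.0-fold higher number from compound 1 to compound 4 (0.70 log units; beyond the scatter), toward weaker inhibition. Compound 4 is expected to give about 3000 nM in this assay, within a range of 800 nM to 10000 nM, with a real chance that only a limit is reported.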

Compound 4, half-maximal inhibitory concentration: > 3000 nM
Compound 4 gave a limit, no number; the forecaster's own chance of this, stated with the estimate: 55%; the middle value lies on the limit itself.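

Among these compounds, the earlier compounds changed only the chlorophenyl group and the methyl, so compound 4 is the first to show that the trifluoromethyl matters as well in this assay: replacing it with amino gives an at least 5.0-fold higher number from compound 1 to compound 4 (0.69 log units; beyond the scatter). Compound 4 gives > 3000 nM, which is a limit and not a number, so the loss could be larger than this step, and how much activity remains cannot be read. All three single changes from compound 1 now end at the same value: the limit of > 3000 nM in this assay, at which 3 of the 4 values shown sit.

Amino differs from trifluoromethyl in both heavy atoms and hydrogen-bond donors and acceptors, and this one swap cannot separate those differences. On these data alone, whether another group at this place, such as a methoxy group or a nitrile, would keep the activity of compound 1 remains open.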